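Bromo in Place of Ethyl: Expected Cytotoxicity Outcome

A few compounds are considered here, and "the series" means these few. Any claim that something is new, unique, unknown or untested is made for them only; others in the source may bear on it.

Compound 1 `CCc1ccc(C(=O)/C=C/c2ccc3c(c2)B(O)OC3)cc1` and compound 2 `COc1cccc(C(=O)CCc2ccc3c(c2)B(O)OC3)c1` were both examined in an ADME assay on L929 cells (Mus musculus) for cytotoxicity, read by resazurin assay, with a stated time of 72 h; a higher number here means a weaker inhibitor, a lower number a stronger inhibitor. Compound 1 gives > 10 ug/mL in this assay, which is a limit of the assay rather than a measured number. Compound 2 also reaches only a limit, > 10 ug/mL. Both measured compounds therefore sit at the same ceiling, as summarised by the limit of > 10 ug/mL in this assay, at which 2 of the 2 values shown sit. Going by the values given here, no step between measured compounds exists, so the two values show only that neither compound reached a readable half-maximal inhibitory concentration.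

Compound 3 `O=C(/C=C/c1ccc2c(c1)B(O)OC2)c1ccc(Br)cc1` has not yet been tested in this assay. It differs from compound 1 by bromo in place of ethyl on an aromatic carbon. With compound 1 at a limit, no direction beyond the scatter can be read from the numbers; the step from compound 1 to compound 3 is expected to be a step that the limit leaves unreadable from compound 1 to compound 3, that is, essentially none. Compound 3 is estimated to give about 15 ug/mL in this assay, within a range from 6 ug/mL to 40 ug/mL, with a good chance that only a limit is reported again.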

Compound 3, half-maximal inhibitory concentration: > 10 ug/mL
Compound 3 gave a limit, no number; the forecaster's own chance of this, stated with the estimate: 65%; the middle value lies beyond the limit too.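

Compound 3 ends at a limit in this assay, as compound 1 does, so bromo in place of ethyl gives no readable step between compound 1 and compound 3, and the three compounds shown share one ceiling: the limit of > 10 ug/mL in this assay, at which 3 of the 3 values shown sit.

The compounds shown leave open how far beyond that limit each compound's true half-maximal inhibitory concentration lies.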